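The compounds below may be only part of what the source reports. "The series", "measured", "known", "first", "only" and "open" are said of these compounds alone.

In a functional assay on HCT-116 cells (Homo sapiens) for antiproliferative activity, read by MTT assay, with a stated time of 48 h (a lower number here means a stronger inhibitor, a higher number a weaker inhibitor), compound 1 `COc1ccc(-c2cc3c(cn2)[nH]c(=O)n3-c2cc(OC)c(OC)c(OC)c2)cc1O` gives 340 nM and compound 2 `COc1ccc(-c2cc3c(cn2)n(C)c(=O)n3-c2cc(OC)c(OC)c(OC)c2)cc1O` gives 1060 nM, the higher of the two numbers. The next analogue, compound 3 `CCn1c(=O)n(-c2cc(OC)c(OC)c(OC)c2)c2cc(-c3ccc(OC)c(O)c3)ncc21`, differs from compound 2 by methyl in place of hydrogen on a saturated chain carbon bound to an aromatic nitrogen, so methyl becomes ethyl. Among the measured compounds shown here, the only measured step that bears on this is the modest one of methyl in place of hydrogen on an aromatic nitrogen, a 3.1-fold higher number from compound 1 to compound 2 (0.49 log units; beyond the scatter). A smaller rise in the same direction is therefore expected, possibly no more than the scatter. The expected change is a 1.4-fold higher number from compound 2 to compound 3 (0.15 log units; within the scatter). For compound 3, the estimate is 1500 nM, within a range of 600 nM to 3800 nM.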

Compound 3, half-maximal inhibitory concentration: > 20000 nM
Compound 3: only a limit was reported (the forecaster's own chance of this, stated with the estimate: 5%); middle value at least 13-fold (1.12 log units) from the limit.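

Compound 3 gives only a limit, not a number, in this assay: the limit of > 20000 nM in this assay, at which 1 of the 3 values shown sits. On the aromatic nitrogen, the change from methyl to ethyl brings an at least 18-fold higher number from compound 2 to compound 3 (1.27 log units; beyond the scatter), far larger than the modest 3.1-fold higher number from compound 1 to compound 2 (0.49 log units; beyond the scatter), so one further carbon costs much more here than the first did. Taken whole, ethyl in place of hydrogen on the aromatic nitrogen gives an at least 58-fold higher number from compound 1 to compound 3 (1.76 log units; beyond the scatter). The compounds shown leave open whether a longer chain, or an ethyl chain ending in an amine or a hydroxyl, behaves the same way on this nitrogen. On these data alone, how weak compound 3 really is also stays open.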